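Carbamoyl to hydroxymethyl on the compound 2 scaffold

A few compounds are considered here, and "the series" means these few. Any claim that something is new, unique, unknown or untested is made for them only; others in the source may bear on it.

In an ADME assay on TZM cells (Homo sapiens) for cytotoxicity, read by XTT assay, with a stated time of 4 days (on this read-out lower numbers stand for higher toxicity in this test and higher numbers for lower toxicity in this test), compound 2 (`Cc1cc(/C=C/C#N)cc(C)c1Oc1cc(Nc2ccc(C#N)cc2)c(N)cc1C(N)=O`) gives > 23600 nM as a limit. Compound 1 (`CNC(=O)c1cc2ncn(-c3ccc(C#N)cc3)c2cc1Oc1c(C)cc(CCC#N)cc1C`) gives > 890000 nM as a limit. Compound 3 (`Cc1cc(CCC#N)cc(C)c1Oc1cc(Nc2ccc(C#N)cc2)c(N)cc1C(N)=O`) gives > 9400 nM as a limit. Compound 2 therefore has no exact number, and neither do the other two. Compound 4 (`Cc1cc(/C=C/C#N)cc(C)c1Oc1cc(Nc2ccc(C#N)cc2)c(N)cc1CO`) differs from compound 2 by hydroxymethyl in place of carbamoyl on an aromatic carbon as hydroxymethyl in place of carbamoyl on an aromatic carbon. Within the data shown here, the only measured step, a step that the two limits leave unreadable from compound 2 to compound 3, concerns another group and gives no size to carry over. No step beyond the scatter is therefore expected in this assay, and another limit is quite possible. The expected outcome is a step that the limit leaves unreadable from compound 2 to compound 4 as an estimate only. Estimated for compound 4: 30000 nM as the middle, with 8000 nM to 100000 nM as the expected range.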

Compound 4, half-maximal cytotoxic concentration: 16300 nM
Compound 4: the middle estimate sits 1.8-fold (0.26 log units) above what was measured; low and high end bracket the measured number.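

In this assay compound 4 gives 16300 nM, the only exact number shown for the series, so exchanging carbamoyl for hydroxymethyl, para to a (4-cyanophenyl)amino group, yields a number rather than a limit. The change reads as an at least 1.4-fold lower number from compound 2 to compound 4 (0.16 log units; that floor lies within the scatter), so no real shift is established. The step has only a floor because compound 2 stands at a limit: the limit of > 23600 nM in this assay, at which 1 of the 4 values shown sits.

The step between the limits of compound 2 and compound 3 cannot be read. On these data alone, how a carboxylic acid or an aminomethyl group at this position would read remains open.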